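Adding a piperidine-bearing group to compound 3

The compounds below may be only part of what the source reports. "The series", "measured", "known", "first", "only" and "open" are said of these compounds alone.

Compound 1 `Cc1csc2cc([C@H](C)Nc3ncnc(N)c3C#N)c(-c3cccc(CN4CCC(CN(C)CC(C)C)CC4)c3)c(=O)n12`: 3.3%
Compound 2 `Cc1csc2cc([C@H](C)Nc3ncnc(N)c3C#N)c(-c3cccc(CN4CCC(CN(C)Cc5ccccn5)CC4)c3)c(=O)n12`: 5.2%
Compound 3 `Cc1csc2cc([C@H](C)Nc3ncnc(N)c3C#N)c(-c3ccccc3)c(=O)n12`: 0%

In an ADME assay on the whole organism (lung, Rattus norvegicus) for metabolic stability, read by LC-MS, with a stated time of 24 h (a higher number here means that more of the compound is left, a lower number that less of the compound is left), compound 3 gives 0%, a value within the scatter of both other compounds. Compound 4 `Cc1csc2cc([C@H](C)Nc3ncnc(N)c3C#N)c(-c3cccc(CN4CCC(N(C)C)CC4)c3)c(=O)n12` differs from compound 3 in one place: (4-(dimethylamino)piperidin-1-yl)methyl in place of hydrogen on an aromatic carbon. In words, (4-(dimethylamino)piperidin-1-yl)methyl stands in place of hydrogen on an aromatic carbon, meta to a large group.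

Within the data shown here, no measured step makes this same change. Among the measured compounds shown here, the one measured step, a number 1.9 percentage points higher from compound 1 to compound 2 (within the scatter), alters only the far end of a longer group and stays within the scatter. Compound 1, at 3.3%, and compound 2, at 5.2%, also carry a group in place of that hydrogen, and neither value stands clear of compound 3. A step beyond the scatter in this assay is therefore not expected, though any small shift may be upward. The expected step is a number 4 percentage points higher from compound 3 to compound 4 (within the scatter). The estimate for compound 4 is 4%, with an expected range from 0% to 12%.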

Compound 4, percent of the compound remaining: 4.8%
Beside the measured number, compound 4's estimate is 0.8 percentage points below it; the range from low to high includes it.
By their numbers in this assay, from the lowest: compounds 3, 1, 4 and 2 (each within the scatter of the next).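

In this assay the first direct test of this change on the aromatic carbon is a number 4.8 percentage points higher from compound 3 to compound 4 (within the scatter) and so does not separate the compound carrying (4-(dimethylamino)piperidin-1-yl)methyl from the one carrying hydrogen. Ending the group in dimethylamino on the saturated ring carbon gives a number 0.4 percentage points lower from compound 2 to compound 4 (within the scatter) and a number 1.5 percentage points higher from compound 1 to compound 4 (within the scatter) so the readings for the three far ends cannot be told apart either. No measurement is available that would explain these numbers.

The compounds shown leave open whether any group on this aromatic carbon can set a compound clearly apart from compound 3 in this assay at all. A carboxylic acid in place of dimethylamino, or a morpholine in place of the piperidine, would be a further test of that question.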